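The compounds below may be only part of what the source reports. "The series", "measured", "known", "first", "only" and "open" are said of these compounds alone.

Of the compounds shown here, three have so far been measured in an in vitro ADME assay on the whole organism (microsomes, liver, Mus musculus) for metabolic stability, read by LC-MS, with a stated time of 24 h, at a dose of 5 mg/kg by the intravenous route; on this read-out lower numbers stand for a shorter-lived compound and higher numbers for a longer-lived compound. Compound 1 `O=[N+]([O-])c1cn2c(n1)OC[C@@H](NCc1ccc(OC(F)(F)F)c(Cl)c1)C2` gives 0.223 h, compound 3 `O=[N+]([O-])c1cn2c(n1)OC[C@@H](NCc1ccc(OC(F)(F)F)c(F)c1)C2` gives 0.393 h, and compound 2 `CCCN(Cc1ccc(OC(F)(F)F)cc1)[C@@H]1COc2nc([N+](=O)[O-])cn2C1` gives 0.0567 h, the lowest of the three numbers. Going by the values given here, the only step between compounds that differ in one place, a 1.8-fold higher number from compound 1 to compound 3 (0.25 log units; within the scatter), concerns the aromatic halogen and does not touch the amine. Compound 4 `CN(Cc1ccc(OC(F)(F)F)cc1)[C@@H]1COc2nc([N+](=O)[O-])cn2C1` differs from compound 2 by hydrogen in place of ethyl on a saturated chain carbon bound to an amine nitrogen. Among the compounds with values here, no measured step bears on this change; compounds 1 and 3, which lack the propyl, give the two higher numbers, but no single-place step links either to compound 2. Compound 4 is therefore expected to show only a modest step, a 1.8-fold higher number from compound 2 to compound 4 (0.25 log units; within the scatter). The half-life of compound 4 is estimated at 0.1 h, within a range of 0.04 h to 0.25 h.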

Compound 4, half-life: 0.183 h
For compound 4 the middle estimate is 1.8-fold (0.26 log units) below the measured one, and the stated range covers the measured number.
By their numbers in this assay, from the lowest: compound 2; then compounds 4, 1 and 3 (each within the scatter of the next, the first and the last beyond it).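

Shortening the chain on the amine nitrogen from propyl to methyl gives a 3.2-fold higher number from compound 2 to compound 4 (0.51 log units; beyond the scatter) in this assay. Going by these compounds alone, this is the first single-place step at this position, and it shows that the half-life responds to this chain, which the earlier halogen step could not show. Nothing available explains the size of this step. From the compounds shown here alone, whether the trend holds for only these two chains stays open, since a single step gives no trend. The compounds shown also leave open how a longer chain, a cyclopropyl ring or a hydroxyl group at this place would read.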